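Chloro-to-fluoro swap across two enone cores

The source may hold more compounds than are shown below. What is called first, only, known or untested is meant among the compounds shown, and "the series" means these compounds.

Compound 1 `CC(=O)OC/C(=C\c1ccc(Cl)cc1)C(=O)c1ccccc1` is measured in a functional assay on HBL-100 cells (Homo sapiens) for inhibition, read by sulforhodamine B assay, with a stated time of 48 h (a higher number here means a weaker inhibitor of growth, a lower number a stronger inhibitor of growth), and gives 2300 nM. Compound 2 `CC(=O)OC/C(=C\c1ccc(F)cc1)C(=O)c1ccccc1` differs by fluoro in place of chloro on an aromatic carbon and in this assay gives 17000 nM, a step of a 7.4-fold higher number from compound 1 to compound 2 (0.87 log units; beyond the scatter). Compound 3 `C=C(C/C(=C\c1ccc(Cl)cc1)C(=O)c1ccccc1)C(=O)c1ccccc1` carries a different core; the difference between the core of compound 3 and the core of compound 1 is not broken down here. In this assay compound 3 gives 17000 nM, level with compound 2 at the digits recorded and well apart from compound 1.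

Compound 4 `C=C(C/C(=C\c1ccc(F)cc1)C(=O)c1ccccc1)C(=O)c1ccccc1` differs from compound 3 by fluoro in place of chloro on an aromatic carbon, the same change as from compound 1 to compound 2. The step of a 4.1-fold higher number from compound 3 to compound 4 (0.61 log units; beyond the scatter) is expected to be of a similar size, because compound 1 to compound 2 gave a 7.4-fold higher number from compound 1 to compound 2 (0.87 log units; beyond the scatter), though compound 3 already sits high. In this assay compound 4 is estimated at 70000 nM, between 20000 nM and 200000 nM.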

Compound 4, concentration for 50% growth inhibition: 14000 nM
For compound 4 the middle estimate is 5.0-fold (0.70 log units) above the measured one; measured number outside the range, below it.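

On the core of compound 3, fluoro in place of chloro gives a 1.2-fold lower number from compound 3 to compound 4 (0.08 log units; within the scatter) in this assay. The rise in the number seen with this change on the core of compound 1 therefore does not carry over to the core of compound 3, and the outcome of the swap differs between these two cores: the same change on two cores in this assay, a 7.4-fold higher number (0.87 log units; beyond the scatter) from compound 1 to compound 2 and a 1.2-fold lower number (0.08 log units; within the scatter) from compound 3 to compound 4, 9.0-fold (0.95 log units) apart, beyond the scatter of two such steps. This rests on a single pair per core, so it shows no general rule for the series and does not reveal what in the cores sets the two steps apart.

Open, from the compounds shown here alone, is whether methoxy or an amine in the same ring place would also read differently on the two cores. Also open, going by these compounds, is how a carboxylic acid or a longer chain there would behave on either core.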